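Replacing propyl with thiophen-2-yl in compound 1

A few compounds are considered here, and "the series" means these few. Any claim that something is new, unique, unknown or untested is made for them only; others in the source may bear on it.

Compound 1 `CCCOC1=CC(=O)c2ccccc2C1=O` gives 51600 nM
Compound 2 `O=C1C=CC(=O)c2c(Oc3ccco3)cccc21` gives 12500 nM

Both numbers come from a functional assay on HeLa cells (Homo sapiens) for cytotoxicity; a lower number here means a stronger inhibitor, a higher number a weaker inhibitor. Compound 1 stands highest of the two, which makes it the weaker inhibitor of the pair, and the gap down to compound 2 lies beyond the usual scatter. Compound 3 `O=C1C=C(Oc2cccs2)C(=O)c2ccccc21` has not yet been measured in this assay. It keeps the core of compound 1 but carries thiophen-2-yl in place of propyl on an oxygen on an unsaturated carbon. Going by the values given here, no measured step shows what this exchange does, so any forecast rests on thin evidence. Among the compounds with values here, the only guide is the range of the two values, and compound 1 at 51600 nM already sits at its top, leaving compound 2 at 12500 nM as the one lower reference. A drop beyond the scatter is therefore expected, towards the number of compound 2, though no change at all cannot be ruled out. The estimated step is a 3.4-fold lower number from compound 1 to compound 3 (0.54 log units; beyond the scatter). For compound 3 the expected value is 15000 nM, with an estimated range from 4000 nM to 50000 nM.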

Compound 3, half-maximal inhibitory concentration: 35300 nM
The estimate for compound 3 lay 2.4-fold (0.37 log units) below the measured number; the range from low to high includes it.
By their numbers in this assay, from the lowest: compound 2; then compounds 3 and 1 (each within the scatter of the next).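

In this assay the exchange of propyl for thiophen-2-yl on an oxygen on an unsaturated carbon now has a measured step, which reads a 1.5-fold lower number from compound 1 to compound 3 (0.16 log units; within the scatter) and lies within the scatter. On the core of compound 1, this place therefore accepts an open chain of propyl or a five-membered aromatic ring with a sulfur atom without a difference that can be told from the scatter, which is what this single pair adds to the earlier numbers, though it does not amount to a rule for other groups. Nothing at hand accounts for why these two groups read alike here.

The compounds shown leave open whether any group on this oxygen can move the number beyond the scatter, for instance a longer chain such as hexyl, a phenyl ring or a chain ending in an amine. They also leave open whether furan-2-yl would read like thiophen-2-yl in this same place on the core of compound 1, and so whether the sulfur atom of the entering ring matters at all.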